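Meta substituent on the benzyl ether: methyl to chloro

This account rests on a few compounds, and the source may have more. Where it says the series, first, only, none or still open, it means among the compounds named here.

Among the compounds with values here, in an assay for inhibition of Amine oxidase [flavin-containing] B (Rattus norvegicus) (on this read-out lower numbers stand for stronger inhibition and higher numbers for weaker inhibition), compound 2 `Cc1cccc(COc2ccc(C3=NN(CCC#N)C(=O)CO3)cc2)c1` gives 31 nM, the lowest of the two numbers measured so far; compound 1 `COc1cccc(COc2ccc(C3=NN(CCC#N)C(=O)CO3)cc2)c1` gives 68 nM. Within the data shown here, the single step in hand, a 2.2-fold lower number from compound 1 to compound 2 (0.34 log units; beyond the scatter), altered the group on that aromatic carbon. Among the measured compounds shown here, compound 3 `N#CCCN1N=C(c2ccc(OCc3cccc(Cl)c3)cc2)OCC1=O` carries the change (chloro in place of methyl on an aromatic carbon); no measured pair sets chloro against methyl, so the direction is open. Only a small step is expected, a 1.1-fold lower number from compound 2 to compound 3 (0.04 log units; within the scatter), not clearly beyond the scatter. For compound 3 the estimate in this assay is 28 nM, within 10 nM to 75 nM.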

Compound 3, half-maximal inhibitory concentration: 13 nM
The estimate for compound 3 lay 2.2-fold (0.33 log units) above the measured number, within the range that was stated.
By their numbers in this assay, from the lowest: compound 3; then compound 2; then compound 1.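

In this assay, chloro on this aromatic carbon goes past methyl, with a 2.4-fold lower number from compound 2 to compound 3 (0.38 log units; beyond the scatter) in the series, so methyl is no longer the best group seen here. Against methoxy the change gives a 5.2-fold lower number from compound 1 to compound 3 (0.72 log units; beyond the scatter) and sets the order of the three compounds as chloro, then methyl, then methoxy. No evidence in hand accounts for this order. On these data alone, whether bromo, trifluoromethyl or an amine at this carbon would fall beyond chloro remains open. Also open, as far as these compounds go, is whether the same order holds when the propionitrile chain on the shared core is replaced by a longer chain.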